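The compounds below may be only part of what the source reports. "The series", "measured", "known", "first", "only" and "open" are said of these compounds alone.

In a toxicity assay on CCRF-CEM cells (Homo sapiens) for cytotoxicity (on this read-out higher numbers stand for lower toxicity in this test and lower numbers for higher toxicity in this test), compound 1 `COc1cccc2c1nc(-c1c(F)cccc1F)n2Cc1c(F)cccc1F` gives 44.3 uM and compound 2 `CNc1cccc2c1nc(-c1c(F)cccc1F)n2Cc1c(F)cccc1F` gives 27.2 uM. Among the measured compounds shown here, compound 2 therefore stands within the scatter of compound 1, the only other compound measured so far. The next compound, compound 3 `CN(C)C(=O)c1cccc2c1nc(-c1c(F)cccc1F)n2Cc1c(F)cccc1F`, carries dimethylcarbamoyl in place of methylamino on an aromatic carbon. For the measured compounds named here, only one measured step bears on this change, a swap of methylamino for methoxy at the same aromatic carbon, and it amounts to a 1.6-fold lower number from compound 1 to compound 2 (0.21 log units; within the scatter). Going by the values given here, no measured compound other than compound 3 carries dimethylcarbamoyl, so that single step is weak guidance and the uncertainty stays wide. The expected change in this assay is a 1.1-fold higher number from compound 2 to compound 3 (0.04 log units; within the scatter), which means no expected shift beyond the scatter. Compound 3 is estimated at 30 uM, with an expected range from 12 uM to 70 uM.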

Compound 3, half-maximal toxic concentration: 80.1 uM
The estimate for compound 3 lay 2.7-fold (0.43 log units) below the measured number; measured number outside the range, above it.
By their numbers in this assay, from the lowest: compounds 2, 1 and 3 (each within the scatter of the next, the first and the last beyond it).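

In this assay, among the compounds shown here, the change to dimethylcarbamoyl on this aromatic carbon gives a 2.9-fold higher number from compound 2 to compound 3 (0.47 log units; beyond the scatter) and so provides the first step at this position that lies beyond the scatter. Measured against methoxy at the same carbon, the group gives a 1.8-fold higher number from compound 1 to compound 3 (0.26 log units; within the scatter) and stays within the scatter, so the position shows a clear difference only between dimethylcarbamoyl and methylamino, with compound 1 not separated from either. Nothing available here accounts for that difference.

The compounds shown leave open whether the carbonyl or the two methyl groups on the amide nitrogen carry the step, which a primary carboxamide at this carbon would begin to separate. They also leave open how a carboxylic acid or a longer chain at the same carbon would read in this assay.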